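From compound 2 to compound 4: adding ethoxycarbonyl

This account rests on a few compounds, and the source may have more. Where it says the series, first, only, none or still open, it means among the compounds named here.

Measured in a functional assay on MCF7 cells (Homo sapiens) for inhibition; on this read-out lower numbers stand for stronger inhibition and higher numbers for weaker inhibition:
- compound 1 `C/C=C/C(C)=C/[C@@]1(C)SC(O)=CC1=O` gives 17.3 ug/mL
- compound 2 `CCCCCC[C@@]1(C)SC(=O)C=C1OC` gives 14 ug/mL
- compound 3 `CCCCCCCC[C@@]1(C)SC(=O)C=C1OC` gives > 50 ug/mL, which is a limit of the assay and not a number

In this assay, among the measured compounds shown here, compound 2 lies within the usual scatter of compound 1, and these two are the only exact numbers so far. Compound 4 `CCCCCC[C@@]1(C)SC(=O)C=C1OCC(=O)OCC` differs from compound 2 by one change, (ethoxycarbonyl in place of hydrogen on a saturated chain carbon bound to an oxygen on an unsaturated carbon). Put another way, methyl becomes (ethoxycarbonyl)methyl. For the measured compounds named here, only one measured step bears on this, and only loosely, as it lies at a different place on the molecule: an at least 3.5-fold higher number from compound 2 to compound 3 (0.55 log units; beyond the scatter). One step proves no rule, but it points towards weaker inhibition, so a modest rise in the number is expected. The expected step is a 1.7-fold higher number from compound 2 to compound 4 (0.23 log units; within the scatter). For compound 4 the estimated value is 24 ug/mL, with an expected range from 10 ug/mL to 50 ug/mL.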

Compound 4, half-maximal inhibitory concentration: 14.2 ug/mL
Compound 4: the middle estimate sits 1.7-fold (0.23 log units) above what was measured, within the range that was stated.
By their numbers in this assay, from the lowest: compounds 2, 4 and 1 (each within the scatter of the next). At a limit, above all of these: compound 3.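

In this assay placing ethoxycarbonyl on a saturated chain carbon bound to an oxygen on an unsaturated carbon gives a 1.0-fold higher number from compound 2 to compound 4 (0.01 log units; within the scatter) and so shows that this position accepts a group of 5 heavy atoms without a step beyond the scatter. Among the compounds shown here, the only earlier step (an at least 3.5-fold higher number from compound 2 to compound 3 (0.55 log units; beyond the scatter)) lies at a different place and rests on a limit of the assay, so it does not carry over to this position. Nothing shown explains why this change gives a step within the scatter. As far as these compounds go, whether an amine, a carboxylic acid or a longer chain at this same place would also stay within the scatter of compound 2 remains open.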